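The source may hold more compounds than are shown below. What is called first, only, known or untested is meant among the compounds shown, and "the series" means these compounds.

Working notes on the series. Compound 1 `CC(C)(C)[C@H]1CC[C@H](N(Cc2ccc(C(=O)NCCC(=O)O)cc2)C(=O)Nc2ccc(C#N)cc2)CC1` carries a tert-butyl on the shared core and a nitrile on the aryl urea; in an in vitro assay on BHK cells for inhibition of Glucagon receptor (Homo sapiens) (on this read-out lower numbers stand for stronger inhibition and higher numbers for weaker inhibition), compound 1 gives 1050 nM. Compound 2 `O=C(O)CCNC(=O)c1ccc(CN(C(=O)Nc2ccc(OC(F)(F)F)cc2)C2CCC(C(=O)NCC3CC3)CC2)cc1` has a (cyclopropylmethyl)carbamoyl group on the core and a trifluoromethoxy group on the aryl urea. In this assay compound 2 gives only a limit, > 10000 nM, so no number stands for it; compound 2 sits at the limit of > 10000 nM in this assay, at which 1 of the 2 values shown sits.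

The step to compound 3 `CCN(CC)C(=O)C1CCC(N(Cc2ccc(C(=O)NCCC(=O)O)cc2)C(=O)Nc2ccc(OC(F)(F)F)cc2)CC1` is a single change: diethylamino in place of (cyclopropylmethyl)amino on a carbonyl carbon. Going by the values given here, no measured pair in this assay isolates this change, so nothing can be read off for it. With compound 2 at a limit, the step from compound 2 to compound 3 cannot be set against a number; the expectation is no movement beyond the scatter, written as a step that the limit leaves unreadable from compound 2 to compound 3, with a fair chance that compound 3 again returns only a limit. Compound 3 is estimated at 15000 nM, in a range from 3000 nM to 60000 nM.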

Compound 3, half-maximal inhibitory concentration: 782 nM
Estimate against measurement, compound 3: 19-fold (1.28 log units) above, outside the stated range (below it).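

In this assay, the group on this carbonyl carbon of the shared core matters to the read-out: an at least 12-fold lower number from compound 2 to compound 3 (1.10 log units; beyond the scatter), with diethylamino in place of (cyclopropylmethyl)amino as the only difference. Both groups have 5 heavy atoms, but the one that leaves has 1 hydrogen-bond donor and a three-membered ring, while the one that enters has 0 hydrogen-bond donors and no ring, and this single pair cannot separate these two differences. The step gives only a lower bound on the size of the change, because compound 2 stands at a limit of the assay: the limit of > 10000 nM in this assay, at which 1 of the 3 values shown sits.

Going by these compounds, it remains open whether a simpler amine on the same carbonyl carbon, such as ethylamino or dimethylamino, would read closer to compound 2 or to compound 3, which would help to separate the amide hydrogen from the ring. Compound 1 and compound 3 differ in both the group on the core and the group on the aryl urea, so the contribution of each place to their values cannot be read from this pair.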